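The source may report more compounds than this note shows. Statements on the series, on what has been measured and on what is new or still open speak of the compounds shown alone.

Compound 1 `Cc1ccc(-c2nc(=O)o[nH]2)c(-c2ccc([C@@H](C)N(CC3CC3)c3nc4c(C(=O)O)cccc4o3)cc2)c1` is followed here through a single change to compound 4 `C[C@H](c1ccc(-c2cc(F)ccc2-c2nc(=O)o[nH]2)cc1)N(CC1CC1)c1nc2c(C(=O)O)cccc2o1`. Within the data shown here, in an ADME assay on the whole organism (Macaca fascicularis) for pharmacokinetics, read by LC-MS, using cassette dosing, at a dose of 1 mg/kg by the oral route (on this read-out lower numbers stand for lower exposure and higher numbers for higher exposure at the dose given), compound 1 gives 2920 nM, the highest of the three numbers known: compound 2 `CCCCN(c1nc2c(NC(C)=O)cccc2o1)[C@H](C)c1ccc(-c2ccccc2-c2nnn[nH]2)cc1` gives 26.6 nM, and compound 3 `CCCCN(c1nc2c(C(=O)NC)cccc2o1)[C@H](C)c1ccc(-c2ccccc2-c2nnn[nH]2)cc1` gives 19.7 nM. Among the measured compounds shown here, the one step that joins two measured compounds, a 1.4-fold lower number from compound 2 to compound 3 (0.13 log units; within the scatter), changes a different part of the shared core than the change at hand and lies within the scatter, so it says nothing about the step from compound 1 to compound 4. That change is fluoro in place of methyl on an aromatic carbon. For the measured compounds named here, no measured pair shows this exchange, so the expectation rests on the size of the change alone, which is small. Compound 4 is therefore expected to show no step beyond the scatter in this assay, the estimated step being a 1.1-fold lower number from compound 1 to compound 4 (0.03 log units; within the scatter). The value expected for compound 4 is 2700 nM, with a range from 1100 nM to 6500 nM.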

Compound 4, maximal plasma concentration: 2900 nM
The estimate for compound 4 lay 1.1-fold (0.03 log units) below the measured number; low and high end bracket the measured number.
By their numbers in this assay, from the lowest: compounds 3 and 2 (each within the scatter of the next); then compounds 4 and 1 (each within the scatter of the next).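

In this assay, fluoro in place of methyl on an aromatic carbon, meta to a large group and para to a group of 6 heavy atoms, gives a 1.0-fold lower number from compound 1 to compound 4 (0.00 log units; within the scatter). Among these compounds, the one earlier step spoke only to a different part of the shared core, so this is the first reading at this position: here the methyl can give way to fluoro with no step beyond the scatter. Nothing shown here bears on why the two numbers agree.

Still open, on these data alone, is whether a larger or differently built group at this position, such as trifluoromethyl, methoxy or an amine, would keep the number in the same range. Open too, as far as these compounds go, is whether the same exchange would read alike on a compound without the carboxylic acid of compound 1.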